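The source may report more compounds than this note shows. Statements on the series, on what has been measured and on what is new or still open speak of the compounds shown alone.

Measured so far in a functional assay on the whole organism (artery, strain albino) with Rattus norvegicus as the target, with a stated time of 900 min, at a dose of 10 mg/kg by the oral route; a lower number here means less inhibition, a higher number more inhibition at the dose given (going by the name of the read-out):

Compound 1, `CC1=C(C(=O)Nc2ccc([N+](=O)[O-])cc2)C(c2cccc([N+](=O)[O-])c2)N=C(SCc2ccccc2)N1`: 14.9%
Compound 2, `CC1=C(C(=O)Nc2ccc([N+](=O)[O-])cc2)C(c2cccc([N+](=O)[O-])c2)N=C(SCc2ccc(Cl)cc2)N1`: 12.3%

Compound 2 has the lowest of the two numbers, and its nearest neighbour is compound 1, whose number lies within the scatter of it, so the two cannot be told apart. Compound 3, `CC1=C(C(=O)Nc2ccc([N+](=O)[O-])cc2)C(c2cccc([N+](=O)[O-])c2)N=C(SCc2ccc(F)cc2)N1`, is not yet measured; it differs from compound 2 by fluoro in place of chloro on an aromatic carbon. Within the data shown here, only one measured step bears on this change: a number 2.6 percentage points lower from compound 1 to compound 2 (within the scatter), which swapped hydrogen for chloro at the same spot and stayed within the scatter. Swapping chloro for fluoro there is expected to move the number no further than that step did, so the step of a number 0.7 percentage points higher from compound 2 to compound 3 (within the scatter) is expected to stay within the scatter. Compound 3 is therefore estimated at 13%, most likely between 5% and 22%.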

Compound 3, a percentage reported as inhibition, in the whole organism at one dose (the size of the read-out at that dose, not a potency): 15.4%
Estimate against measurement, compound 3: 2.4 percentage points below; measured number inside the range.
By their numbers in this assay, from the lowest: compounds 2, 1 and 3 (each within the scatter of the next).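

Across the halogens, the step of a number 3.1 percentage points higher from compound 2 to compound 3 (within the scatter) shows that chloro and fluoro on this aromatic carbon cannot be told apart in this assay. Fluoro can also be set against plain hydrogen at the same spot, and the step of a number 0.5 percentage points higher from compound 1 to compound 3 (within the scatter) shows that these two cannot be told apart either. Hydrogen, chloro and fluoro therefore all lie within the scatter of one another here, and nothing available explains this lack of separation.

The compounds shown leave open whether a methoxy group, an amine or a carboxylic acid on this aromatic carbon would step outside the scatter, and whether a longer chain in place of the benzyl group on the sulfur would do so. As far as these compounds go, both nitro groups are the same in all three compounds, so their contribution also remains open.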